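Cyclopropyl for methyl on the oxadiazole of compound 1

The compounds below may be only part of what the source reports. "The series", "measured", "known", "first", "only" and "open" are said of these compounds alone.

Compound 1, `Cc1cc(CCCOc2c(C)cc(-c3noc(C)n3)cc2C)on1`: 0.45 h in an in vitro ADME assay on microsomes from liver (Simiiformes); on this read-out lower numbers stand for a shorter-lived compound and higher numbers for a longer-lived compound
Compound 2, `COCc1cc(CCCOc2c(C)cc(-c3noc(C4CC4)n3)cc2C)on1`: > 2.5 h, a limit of this assay
Compound 3, `Cc1cc(-c2noc(C3CC3)n2)cc(C)c1OCCCc1cc(C2CC2)no1`: > 2.5 h, a limit of this assay

Among the compounds with values here, compound 1 holds the only number here; the other two values are limits. The step that the two limits leave unreadable from compound 2 to compound 3 cannot be read because both its values sit at the limit of > 2.5 h in this assay, at which 2 of the 3 values shown sit. Compound 4, `Cc1cc(CCCOc2c(C)cc(-c3noc(C4CC4)n3)cc2C)on1`, differs from compound 1 by cyclopropyl in place of methyl on an aromatic carbon. Within the data shown here, no measured step covers this change. Compound 2 and compound 3, which carry the entering cyclopropyl, sit at the limit of > 2.5 h in this assay, at which 2 of the 3 values shown sit, while compound 1 does not. Compound 4 is therefore expected to be longer-lived, with an expected step of a 3.3-fold higher number from compound 1 to compound 4 (0.52 log units; beyond the scatter). The estimate for compound 4 is 1.5 h, expected between 0.5 h and 3.5 h.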

Compound 4, half-life: 2.23 h
Compound 4: middle estimate off by 1.5-fold (0.17 log units), on the low side, and the stated range covers the measured number.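

With nothing else changed, the move from 5-methyl-1,2,4-oxadiazol-3-yl to 5-cyclopropyl-1,2,4-oxadiazol-3-yl gives a step of its own in this assay: a 5.0-fold higher number from compound 1 to compound 4 (0.70 log units; beyond the scatter). Compared with the two compounds that also carry this cyclopropyl, the steps are an at least 1.1-fold lower number from compound 3 to compound 4 (0.04 log units; that floor lies within the scatter) and an at least 1.1-fold lower number from compound 2 to compound 4 (0.04 log units; that floor lies within the scatter). Neither shows a real difference, and the true size of each stays unknown: the limit of > 2.5 h in this assay, at which 2 of the 4 values shown sit.

As far as these compounds go, whether ethyl or isopropyl at this position would serve as well as cyclopropyl stays open. So does how far the methoxymethyl of compound 2 and the cyclopropyl of compound 3 extend the half-life.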